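This account rests on a few compounds, and the source may have more. Where it says the series, first, only, none or still open, it means among the compounds named here.

Of the compounds shown here, two have been tested so far in an assay on isolated protein for inhibition of cathepsin S (Homo sapiens); on this read-out lower numbers stand for stronger inhibition and higher numbers for weaker inhibition. Compound 1, with structure `CC(C)C[C@H](NC(=O)OCc1ccccc1)C(=O)NCCNc1ccc(OCCn2ccnc2)cc1`, gives 5700 nM in this assay. Compound 2, with structure `CCc1ccc(C(=O)N[C@@H](CC(C)C)C(=O)NCCNc2ccc(OCc3ccccc3)cc2)cc1`, gives 4900 nM in this assay. Compound 1 sits at one end of this pair, yet its gap to compound 2 lies within the usual scatter of repeated measurements, so the two cannot be told apart on these numbers.

Compound 3, with structure `CC(C)C[C@H](NC(=O)OCc1ccccc1)C(=O)NCCNc1ccc(OCC2CC2)cc1`, has not yet been measured. It differs from compound 1 in one place: cyclopropyl in place of (1H-imidazol-1-yl)methyl on a saturated chain carbon bound to an oxygen on an aromatic ring. Going by the values given here, nothing among the measured compounds shows what such a swap does in this assay, since compound 1 and compound 2 differ from each other in several places at once and no single-change pair has been measured.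

Among the compounds with values here, with no comparable step to lean on, the expectation for compound 3 is a step from compound 1 that stays within the scatter, with a 1.1-fold higher number from compound 1 to compound 3 (0.02 log units; within the scatter) as the expected size. Compound 3 is therefore estimated to give 6000 nM in this assay, within an expected range from 2000 nM to 18000 nM.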

Compound 3, half-maximal inhibitory concentration: 2800 nM
Compound 3: middle estimate off by 2.1-fold (0.33 log units), on the high side; the measured number falls inside the stated range.
By their numbers in this assay, from the lowest: compounds 3, 2 and 1 (each within the scatter of the next, the first and the last beyond it).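

In this assay, going by these compounds alone, this is the first pair that differs in one place, and it gives a 2.0-fold lower number from compound 1 to compound 3 (0.31 log units; beyond the scatter). The group on the saturated chain carbon bound to an oxygen on an aromatic ring can therefore shift the read-out, if only modestly, and the (1H-imidazol-1-yl)methyl group, with its five-membered aromatic ring and 2 hydrogen-bond acceptors, is not needed for the inhibition seen in compound 1, since cyclopropyl, with 3 heavy atoms and 0 hydrogen-bond acceptors, does not weaken it. No measurement shown here tells which of these differences in the two groups accounts for the step.

From the compounds shown here alone, a single swap cannot separate the loss of the aromatic ring from the change in group size or the removal of the ring nitrogens, so the contribution of each remains open. Going by these compounds, a plain alkyl chain such as n-butyl, a dimethylamine at the end of the chain, or a carboxylic acid in the same place would each test a different part of that question, and how far this position can move the read-out is still unknown.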